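Notes on the carbonyl substituent, compound 3 to compound 4

This account rests on a few compounds, and the source may have more. Where it says the series, first, only, none or still open, it means among the compounds named here.

Compound 1 `CCCN1CC[C@H](NC(=O)C[C@@H]2C(=O)NC=CN2S(=O)(=O)c2ccc(C)cc2)C(C)(C)C1` gives 0.51 nM in an in vitro functional assay on cells for antagonist activity at B1 bradykinin receptor (Homo sapiens), read by luminescence and calcium flux, with a stated time of 2 h; a lower number here means a stronger inhibitor, a higher number a weaker inhibitor.
Compound 2 `Cc1cc(S(=O)(=O)N2C=CNC(=O)[C@H]2CC(=O)N[C@H]2CCNCC2(C)C)c(C)cc1Cl` gives 0.31 nM in this assay.
Compound 3 `Cc1cc(S(=O)(=O)N2C=CNC(=O)[C@H]2CC(=O)N2CCC[C@H](N3CCCC3)C2)c(C)cc1Cl` gives 38 nM in this assay.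

Compound 3 stands at the highest number of the three, well beyond the scatter from both compound 1 and compound 2. For the measured compounds named here, the one measured step that reaches it, a 120-fold higher number from compound 2 to compound 3 (2.09 log units; beyond the scatter), shows how strongly the group on the carbonyl carbon governs the read-out in this set.

Compound 4 `Cc1cc(S(=O)(=O)N2C=CNC(=O)[C@H]2CC(=O)N2CCC3(CCN(C)C3)C2)c(C)cc1Cl` takes the next step from compound 3: a group of 10 heavy atoms (8 carbon, 2 nitrogen; 2 five-membered non-aromatic rings with 1 hetero atom each) in place of a group of 11 heavy atoms (9 carbon, 2 nitrogen; one five-membered non-aromatic ring with 1 hetero atom, one six-membered non-aromatic ring with 1 hetero atom), on a carbonyl carbon. Going by the values given here, no measured step touches this particular pair of groups, so the only guide is that compound 3, carrying a ring-bearing group on the carbonyl carbon, already sits far above compound 1 and compound 2, and compound 4 keeps a group of the same general kind in the same place. The expectation is therefore for no step beyond the scatter, with the number for compound 4 staying near that of compound 3, though the wide spread seen in a 120-fold higher number from compound 2 to compound 3 (2.09 log units; beyond the scatter) leaves room for a larger move in either direction.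

Compound 4 is estimated at 30 nM, with a range of 5 nM to 200 nM, an expected step of a 1.3-fold lower number from compound 3 to compound 4 (0.10 log units; within the scatter).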

Compound 4, half-maximal inhibitory concentration: 1.53 nM
Compound 4: the middle estimate sits 20-fold (1.29 log units) above what was measured; measured number below the stated range.
By their numbers in this assay, from the lowest: compounds 2 and 1 (each within the scatter of the next); then compound 4; then compound 3.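

Working notes on the group on the carbonyl carbon: in this assay the high number of compound 3 is not a fixed result of this kind of ring-bearing group, since a 25-fold lower number from compound 3 to compound 4 (1.40 log units; beyond the scatter) is a large drop, and both groups count 0 hydrogen-bond donors, 1 hydrogen-bond acceptor and no net charge, so these counts do not separate the two compounds. The group with 2 five-membered non-aromatic rings with 1 hetero atom each closes much of the gap to the group in compound 2, although a 4.9-fold higher number from compound 2 to compound 4 (0.69 log units; beyond the scatter) is still a modest rise beyond the scatter, against the large rise of a 120-fold higher number from compound 2 to compound 3 (2.09 log units; beyond the scatter) for the group it replaced. No measurement available here offers an explanation for either step.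

The change from compound 3 to compound 4 alters ring sizes, heavy-atom count and the defined stereocentre at once, so the compounds shown do not assign the drop to any one of these. On these data alone, how a group carrying a primary amine or a carboxylic acid would read on this carbonyl carbon remains open, as does the effect of a longer chain in place of the methyl group of compound 4.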